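Cyclopropyl for Hydroxyethyl: Solubility Outlook for Compound 4

The compounds below may be only part of what the source reports. "The series", "measured", "known", "first", "only" and "open" are said of these compounds alone.

Compound 1, `CNC(=O)c1cc(C(=O)N[C@H]2[C@@H]3COC[C@@H]32)c([C@@H](C)c2ccccc2)o1`: >= 131 ug/mL
Compound 2, `CNC(=O)c1cc(C(=O)N[C@H]2CC[C@H](OC)CC2)c([C@@H](C)c2ccccc2)o1`: >= 192 ug/mL
Compound 3, `CNC(=O)c1cc(C(=O)NCCO)n([C@@H](C)c2ccccc2)n1`: >= 139 ug/mL

In a physicochemical assay for solubility (a lower number here means a less soluble compound, a higher number a more soluble compound), compound 1 reaches >= 131 ug/mL, which is a limit of the assay. Compound 2 reaches >= 192 ug/mL, again a limit. Compound 3 reaches >= 139 ug/mL, likewise a limit, so its standing among the three is known only as a floor. Among the measured compounds shown here, the single measured step, a step that the two limits leave unreadable from compound 1 to compound 2, gives no size to lean on. Compound 4, `CNC(=O)c1cc(C(=O)NC2CC2)n([C@@H](C)c2ccccc2)n1`, differs from compound 3 by cyclopropyl in place of 2-hydroxyethyl on an amide-type nitrogen. For the measured compounds named here, no measured step carries this change, so the direction rests on the floors alone. Compound 4 is expected to sit an at least 1.3-fold lower number from compound 3 to compound 4 (0.14 log units; that floor lies within the scatter), most likely near 100 ug/mL, with a range from 40 ug/mL to 200 ug/mL.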

Compound 4, solubility: >= 165 ug/mL
Compound 4 ended at the assay's limit (the forecaster's own chance of this, stated with the estimate: 40%); at least 1.6-fold (0.21 log units) between middle value and limit.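

In this assay, among the compounds shown here, compound 3 and compound 4 both stand at limits of the assay, so no step between them can be read. From the compounds shown here alone, the true values of both, and which of the two is the more soluble, remain open.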